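The source may report more compounds than this note shows. Statements on the series, on what has been measured and on what is new or still open speak of the compounds shown alone.

Working notes on the series. Among the measured compounds shown here, compound 1 `COc1ccc(S(=O)(=O)N2CCc3cccc(NC(=O)c4ccncc4)c32)cc1` is the reference point: in a functional assay on KB cells (Homo sapiens) for cytotoxicity (a higher number here means a weaker inhibitor, a lower number a stronger inhibitor), compound 1 gives 9.6 nM, the lowest of the three numbers measured so far. The nearest of the others is compound 3 `COc1ccc(S(=O)(=O)N2CCc3cc(Br)cc(NC(=O)c4ccncc4)c32)cc1`, which gives 91 nM, and the step of a 9.5-fold higher number from compound 1 to compound 3 (0.98 log units; beyond the scatter). Furthest is compound 2 `COc1ccc(S(=O)(=O)N2CCc3cccc(NS(=O)(=O)c4ccc([N+](=O)[O-])cc4)c32)cc1`, which differs in more than one place from the reference; compound 2 gives 1100 nM.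

Compound 4 `COC(=O)c1ccc(C(=O)Nc2cccc3c2N(S(=O)(=O)c2ccc(OC)cc2)CC3)cc1` carries the change (4-(methoxycarbonyl)phenyl in place of pyridin-4-yl on a carbonyl carbon). For the measured compounds named here, no measured step touches the group on this carbonyl carbon; the only measured step, the one to compound 3, concerns a different part of the core and so does not bear on the change. The values of compound 1 and compound 2 show only that altering the part of the molecule attached to the ring nitrogen's neighbourhood can cost a great deal, but that pair differs in several places at once.

With nothing directly comparable, a loss against compound 1 is expected, of moderate size: the estimated step is a 5.2-fold higher number from compound 1 to compound 4 (0.72 log units; beyond the scatter). Compound 4 is expected to give 50 nM in this assay, within a range of 10 nM to 300 nM.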

Compound 4, half-maximal inhibitory concentration: 376 nM
Estimate against measurement, compound 4: 7.5-fold (0.88 log units) below; measured number outside the range, above it.
By their numbers in this assay, from the lowest: compound 1; then compound 3; then compound 4; then compound 2.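

Among the compounds shown here, the first measured change at the group on this carbonyl carbon shows that the position is sensitive in this assay: replacing pyridin-4-yl with 4-(methoxycarbonyl)phenyl on the shared core gives a 39-fold higher number from compound 1 to compound 4 (1.59 log units; beyond the scatter). For the compounds shown here, the single step changes two things at once, removing the ring nitrogen and adding the methoxycarbonyl group, so the loss cannot be assigned to either one. No available evidence accounts for the size of this loss.

Going by these compounds, it remains open whether an unsubstituted phenyl group on this carbonyl carbon would retain the value of compound 1 or show a similar loss, which would help separate the contribution of the ring nitrogen from that of the ester. On these data alone, it is also open how a carboxylic acid or a primary amine in place of the methoxycarbonyl group would read out.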